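The source may report more compounds than this note shows. Statements on the series, on what has been measured and on what is new or still open speak of the compounds shown alone.

Measured compounds:
Compound 1 `COc1n[nH]c2ncc(-c3cn(-c4c(F)ccc(NC(=O)c5cccc(Cl)c5)c4F)nn3)cc12` gives 54.3 nM in an assay on Sf9 cells for inhibition of mitogen-activated protein kinase kinase kinase 20 (Homo sapiens), read by ADP-Glo, with a stated time of 30 min; a higher number here means a weaker inhibitor, a lower number a stronger inhibitor.
Compound 2 `COc1n[nH]c2ncc(-c3cn(-c4c(F)ccc(NS(=O)(=O)c5cccc(C#N)c5)c4F)nn3)cc12` gives 3.3 nM in this assay.

Within the data shown here, compound 2 stands at the lowest number of the two; the only neighbour is compound 1, and the step of a 16-fold lower number from compound 1 to compound 2 (1.22 log units; beyond the scatter) lies beyond the scatter. That step combined two changes at once, a sulfonyl in place of a carbonyl together with a cyano in place of a chloro on the outer ring, so it does not isolate what a single change on that ring does.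

Compound 3 `COc1n[nH]c2ncc(-c3cn(-c4c(F)ccc(NS(=O)(=O)c5cccc(C(C)C)c5)c4F)nn3)cc12` has not yet been tested. It differs from compound 2 by isopropyl in place of cyano on an aromatic carbon, that is, 3-cyanophenyl becomes 3-isopropylphenyl, while the sulfonamide link and the shared core stay. Among the measured compounds shown here, no measured step here changes only the group on that outer ring, so nothing on hand points firmly in either direction. The expectation is therefore a small step, a 1.8-fold higher number from compound 2 to compound 3 (0.26 log units; within the scatter), plausibly within the scatter. Compound 3 is estimated at 6 nM, with a range from 1.5 nM to 25 nM.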

Compound 3, half-maximal inhibitory concentration: 6.9 nM
Compound 3: the middle estimate sits 1.2-fold (0.06 log units) below what was measured, and the stated range covers the measured number.
By their numbers in this assay, from the lowest: compound 2; then compound 3; then compound 1.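

In this assay, among these compounds, this is the first step that changes only the group on the outer ring: with isopropyl in place of cyano on an aromatic carbon, there is a 2.1-fold higher number from compound 2 to compound 3 (0.32 log units; beyond the scatter), a modest loss just beyond the usual scatter, so the cyano is not essential for a strong number at this position, and an all-carbon group of similar reach comes close to it. Swapping the whole group on the nitrogen still leaves a 7.9-fold lower number from compound 1 to compound 3 (0.90 log units; beyond the scatter), which keeps most of the gain seen with compound 2, although this step again changes the link and the ring group together. No measurement on hand bears on why cyano and isopropyl differ by this amount.

What the compounds shown leave open is how that gain divides between the sulfonyl link and the group on the outer ring, which a 3-chlorophenyl group on the sulfonyl would help to separate. Also open, on these data alone, is how this position responds to a group of a different kind, such as an amine, a carboxylic acid or a longer alkyl chain.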